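Swapping the Pyridinyl Ring of Compound 2 for Tolyl

A few compounds are considered here, and "the series" means these few. Any claim that something is new, unique, unknown or untested is made for them only; others in the source may bear on it.

Compound 2 `Cn1c(-c2cccnc2)nc2c(NC3CCCC3)ncnc21` gives 242 nM in an assay on CHO cells for displacement of a labelled ligand from adenosine receptor A1 (Homo sapiens), read by scintillation counting, with a stated time of 3 h (on this read-out lower numbers stand for stronger inhibition and higher numbers for weaker inhibition), the highest of the two numbers available, the other belonging to compound 1 `Cn1c(-c2ccc(O)cc2)nc2c(NC3CCCC3)ncnc21`, which in this assay gives 17 nM. Within the data shown here, the only measured step, a 14-fold higher number from compound 1 to compound 2 (1.15 log units; beyond the scatter), is the reference point for what follows. Compound 3 `Cc1cccc(-c2nc3c(NC4CCCC4)ncnc3n2C)c1` arises from compound 2 by the change (3-methylphenyl in place of pyridin-3-yl on an aromatic carbon). Among the measured compounds shown here, no step in the set covers exactly this exchange; the one step that touches the same position shows that a change of the aryl group alone can move the number far, and that the version carrying pyridin-3-yl sits at the weak end. Since compound 1 reaches 17 nM with a different aryl group at the same carbon, replacing the pyridin-3-yl of compound 2 is expected to give a lower number, though a return to the level of compound 1 is not assumed. For compound 3 the expected value in this assay is 60 nM, within a range of 15 nM to 250 nM, meaning an estimated step of a 4.0-fold lower number from compound 2 to compound 3 (0.61 log units; beyond the scatter).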

Compound 3, inhibition constant: 6.2 nM
For compound 3 the middle estimate is 9.7-fold (0.99 log units) above the measured one; the measured number lies below the stated range.
By their numbers in this assay, from the lowest: compound 3; then compound 1; then compound 2.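

In this assay, the exchange of pyridin-3-yl for 3-methylphenyl gives a 39-fold lower number from compound 2 to compound 3 (1.59 log units; beyond the scatter) and so shows that an aryl group with 0 hydrogen-bond donors and 0 hydrogen-bond acceptors can sit on this aromatic carbon of the shared core and still give a low number. The same group also passes the 4-hydroxyphenyl group, with a 2.7-fold lower number from compound 1 to compound 3 (0.44 log units; beyond the scatter) as a modest step that is nevertheless beyond the usual scatter, so among these three compounds the lowest number does not depend on the hydroxyl group of compound 1. No measurement accompanying these compounds accounts for the size of either step.

The compounds shown leave open how much of the step belongs to the methyl group and how much to the loss of the ring nitrogen, a question that plain phenyl could help to settle. They also leave open how far this position accepts other groups on the ring, such as methoxy, an amine or a carboxylic acid in place of the methyl group.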